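A few compounds are considered here, and "the series" means these few. Any claim that something is new, unique, unknown or untested is made for them only; others in the source may bear on it.

Measured so far:
- compound 1 `O=c1nc(N2CCN(CC3CCCCC3)CC2)sc2c([N+](=O)[O-])cc(C(F)(F)F)cc12`: 1400000 nM
- compound 2 `O=c1nc(N2CCC3(CCN(Cc4ccccc4)C3)CC2)sc2c([N+](=O)[O-])cc(C(F)(F)F)cc12`: 289000 nM

In an ADME assay on Vero cells (Chlorocebus sabaeus) for cytotoxicity, read by MTT assay, with a stated time of 72 h (on this read-out lower numbers stand for higher toxicity in this test and higher numbers for lower toxicity in this test), compound 2 gives 289000 nM, the lower of the two numbers. Compound 1 stands higher at 1400000 nM, and this gap lies beyond the usual scatter. The next compound to be tested is compound 3 `COc1ccc(CN2CCC3(CCN(c4nc(=O)c5cc(C(F)(F)F)cc([N+](=O)[O-])c5s4)CC3)C2)cc1`, which shares its core with compound 2 and turns the benzyl group into 4-methoxybenzyl, with methoxy in place of hydrogen on an aromatic carbon. Going by the values given here, no pair of measured compounds shows a change of this kind, so the data offer no direct guide to it. In this assay, only a small step is expected, within the scatter and without a firm direction. The estimated change is a 1.2-fold lower number from compound 2 to compound 3 (0.06 log units; within the scatter). For compound 3 the expected value is 250000 nM, with an estimated range from 110000 nM to 550000 nM.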

Compound 3, half-maximal cytotoxic concentration in the Vero assay: 86200 nM
Compound 3: the middle estimate sits 2.9-fold (0.46 log units) above what was measured; the whole stated range lies above it.
By their numbers in the Vero assay, from the lowest: compound 3; then compound 2; then compound 1.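

Going by these compounds alone, in the Vero assay, where compound 2 gives 289000 nM and compound 3 gives 86200 nM, the benzyl group of compound 2 gives the first reading of a change on this six-membered aromatic ring: methoxy in place of hydrogen, para to a large group, gives a 3.4-fold lower number from compound 2 to compound 3 (0.53 log units; beyond the scatter), so adding 2 heavy atoms at this place is enough to move the number beyond the scatter. In a physicochemical assay for solubility, read by HPLC, with a stated time of 12 h, at pH 2 (a higher number here means a more soluble compound, a lower number a less soluble compound), where compound 2 gives 1.56 ug/mL and compound 3 gives 1.4 ug/mL, the same change reads a 1.1-fold lower number from compound 2 to compound 3 (0.05 log units; within the scatter), so the step appears in only one of the two assays. Nothing measured here accounts for the step in the first of these readings.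

The compounds shown leave open whether another group on this aromatic carbon, such as a hydroxyl, a chlorine atom or an amine, would move the number the same way. They also leave open whether a longer ether chain in place of methoxy would go further.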